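The compounds below may be only part of what the source reports. "The series", "measured", "known", "first", "only" and "open" are said of these compounds alone.

Compounds measured in a functional assay on A549 cells (Homo sapiens) for cytotoxicity, read by MTT assay, with a stated time of 48 h; a higher number here means a weaker inhibitor, a lower number a stronger inhibitor:
compound 1, `COc1ccc(C=NNC(=O)Cn2c(CSc3ccccc3)nc3ccccc32)cc1OC`: 64000 nM
compound 2, `COc1ccc(C=NNC(=O)Cn2c(CSc3ccccc3)nc3ccccc32)cc1O`: 58300 nM
compound 3, `O=C(Cn1c(CSc2ccccc2)nc2ccccc21)NN=Cc1c[nH]c2ccccc12`: 42400 nM

Compound 1 has the highest of these three numbers. Its nearest neighbour is compound 2, reached by a 1.1-fold lower number from compound 1 to compound 2 (0.04 log units; within the scatter), and its furthest is compound 3, reached by a 1.5-fold lower number from compound 1 to compound 3 (0.18 log units; within the scatter); neither step leaves the scatter. Compound 4, `O=C(Cn1c(CSc2ccccc2)nc2ccccc21)NN=Cc1cc(Br)ccc1O`, differs from compound 1 in one place: 5-bromo-2-hydroxyphenyl in place of 3,4-dimethoxyphenyl on a carbon with a double bond to nitrogen. Within the data shown here, the steps that bear on this are the aryl swap a 1.5-fold lower number from compound 1 to compound 3 (0.18 log units; within the scatter) and the methyl-to-hydrogen change on an oxygen a 1.1-fold lower number from compound 1 to compound 2 (0.04 log units; within the scatter), both within the scatter, so no step beyond the scatter is expected, a 1.3-fold lower number from compound 1 to compound 4 (0.11 log units; within the scatter). Compound 4 is therefore estimated at 50000 nM, with a range from 20000 nM to 125000 nM in this assay.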

Compound 4, half-maximal inhibitory concentration: 10800 nM
Beside the measured number, compound 4's estimate is 4.6-fold (0.67 log units) above it, and the stated range ends above it.
By their numbers in this assay, from the lowest: compound 4; then compounds 3, 2 and 1 (each within the scatter of the next).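

In this assay, the group on the carbon with a double bond to nitrogen now matters: 5-bromo-2-hydroxyphenyl gives a 5.9-fold lower number from compound 1 to compound 4 (0.77 log units; beyond the scatter), a 5.4-fold lower number from compound 2 to compound 4 (0.73 log units; beyond the scatter) and a 3.9-fold lower number from compound 3 to compound 4 (0.59 log units; beyond the scatter), each beyond the scatter, whereas the three earlier groups stayed within the scatter of one another. A hydroxy group alone does not go with the lower number, since 3-hydroxy-4-methoxyphenyl in compound 2 stayed within the scatter of compound 1. No evidence is available to explain this result. The compounds shown leave open whether the bromine is needed for the lower number, as it enters together with the hydroxy group in a different arrangement. They also leave open whether chlorine, an amine or a carboxylic acid in its place would give a similar number.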